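Raising Methyl to Ethyl on the Aryl Ring

A few compounds are considered here, and "the series" means these few. Any claim that something is new, unique, unknown or untested is made for them only; others in the source may bear on it.

Compound 1 `CCOC(=O)C1=C(Nc2ccc(OC)cc2)S/C(=C\c2ccc[nH]2)C1=O` gives in a functional assay on A549 cells (Homo sapiens) for inhibition, read by MTT assay, with a stated time of 72 h, tested at 10 uM (a higher number here means more inhibition at the concentration tested (going by the name of the read-out), a lower number less inhibition), only a limit, < 10%.
Compound 2 `CCOC(=O)C1=C(Nc2ccc(C)cc2)S/C(=C\c2ccc[nH]2)C1=O` gives in this assay a value of 20.9%.

Compound 2 therefore holds the only true number shown, while compound 1 sits at a limit (the limit of < 10% in this assay, at which 1 of the 2 values shown sits). Within the data shown here, the one measured step, a number at least 10.9 percentage points higher from compound 1 to compound 2 (beyond the scatter), concerns methyl in place of methoxy on an aromatic carbon, a different change. Compound 3 `CCOC(=O)C1=C(Nc2ccc(CC)cc2)S/C(=C\c2ccc[nH]2)C1=O` differs from compound 2 by methyl in place of hydrogen on a saturated chain carbon bound to an aromatic carbon. Among the measured compounds shown here, no measured step covers this change, so no shift beyond the scatter is expected. Compound 3 is estimated at 22%, between 8% and 40%. That expectation amounts to a step of a number 1.1 percentage points higher from compound 2 to compound 3 (within the scatter).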

Compound 3, a percentage reported as inhibition, at one concentration (the size of the read-out at that concentration, not a potency): 17.5%
For compound 3 the middle estimate is 4.5 percentage points above the measured one; the range from low to high includes it.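

In this assay, the added methyl on the saturated chain carbon bound to an aromatic carbon gives a number 3.4 percentage points lower from compound 2 to compound 3 (within the scatter), so 4-methylphenyl and 4-ethylphenyl cannot be told apart here. The reading for compound 1 is a limit, not a true number: the limit of < 10% in this assay, at which 1 of the 3 values shown sits. Ethyl in place of methoxy gives a number at least 7.5 percentage points higher from compound 1 to compound 3 (that floor lies within the scatter), so this comparison, unlike the one with methyl in place of methoxy, stays unsettled.

From the compounds shown here alone, whether a longer chain such as propyl, or an amine or a carboxylic acid, in place of the ethyl would shift the reading remains open.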